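This account rests on a few compounds, and the source may have more. Where it says the series, first, only, none or still open, it means among the compounds named here.

Compounds measured so far:
- compound 1 `COc1ccc(OC)c(/C=C/c2nnc(Nc3ccc(Cl)cc3)o2)c1`, 4210 nM
- compound 2 `COc1ccc(OC)c(/C=C/C(=O)N/N=C/c2ccc(Cl)cc2)c1`, 982 nM

In a functional assay on SN12C cells (Homo sapiens) for antiproliferative activity, read by sulforhodamine B assay, with a stated time of 48 h (on this read-out lower numbers stand for stronger inhibition of growth and higher numbers for weaker inhibition of growth), compound 2 gives the lower of the two numbers; compound 1 lies beyond the scatter from it. Compound 3 `COc1ccc(OC)c(/C=C/C(=O)N/N=C/c2ccccc2)c1` differs from compound 2 by hydrogen in place of chloro on an aromatic carbon. For the measured compounds named here, no measured pair shows this change, so the size of the step is taken loosely from similar removals of a halogen on an aryl ring. The step is expected to be a small loss of a 1.8-fold higher number from compound 2 to compound 3 (0.26 log units; within the scatter). Compound 3 is estimated at 1800 nM, in the range 700 nM to 4500 nM.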

Compound 3, concentration for 50% growth inhibition: 4170 nM
For compound 3 the middle estimate is 2.3-fold (0.36 log units) below the measured one; measured number inside the range.
By their numbers in this assay, from the lowest: compound 2; then compounds 3 and 1 (each within the scatter of the next).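

In this assay, for the compounds shown here, 4-chlorophenyl to phenyl gives a 4.2-fold higher number from compound 2 to compound 3 (0.63 log units; beyond the scatter), the first step read across a single change. The place para to a large group is therefore not indifferent to what it carries, and chloro there goes with the lower number. Nothing measured here bears on the reason for this step.

Open, from the compounds shown here alone, is whether fluoro, methoxy or an amine at this place would give a number near that of compound 2 or that of compound 3. Also open, going by these compounds, is whether the same change on the core of compound 1 would give a step of similar size.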